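The source may hold more compounds than are shown below. What is called first, only, known or untested is meant among the compounds shown, and "the series" means these compounds.

Series notes, step from compound 2 to compound 3.

Compound 1 `O=S(=O)(c1ccccc1Cl)c1cn(C2CCCNC2)c2ncccc12` gives in a functional assay on HeLa cells for agonist activity at 5-hydroxytryptamine receptor 6 (Homo sapiens), read by cAMP accumulation and immunoassay (a lower number here means that less compound is needed, a higher number that more compound is needed for the effect), a value of 50 nM. Compound 2 `O=S(=O)(c1cccc(Br)c1)c1cn(C2CCCNC2)c2ncccc12` gives in this assay a value of 72 nM. Among the two numbers measured, compound 2 has the highest, with compound 1 nearest; the step of a 1.4-fold higher number from compound 1 to compound 2 (0.16 log units; within the scatter) is within the scatter, so no order between the two is claimed.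

Compound 3 `O=S(=O)(c1cccc(F)c1)c1cn(C2CCCNC2)c2ncccc12` is not yet measured. It differs from compound 2 by fluoro in place of bromo on an aromatic carbon, meta to a large group on the phenyl ring of the sulfonyl group. Among the measured compounds shown here, the only measured step that bears on this change is a 1.4-fold higher number from compound 1 to compound 2 (0.16 log units; within the scatter), a halogen swap on the same ring that stayed within the scatter. A similar outcome is therefore expected here: the step of a 1.3-fold higher number from compound 2 to compound 3 (0.10 log units; within the scatter) is expected to stay within the scatter, with no clear direction. For compound 3 a value of 90 nM is estimated, with a range from 35 nM to 250 nM.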

Compound 3, half-maximal effective concentration: 67 nM
Beside the measured number, compound 3's estimate is 1.3-fold (0.13 log units) above it, within the range that was stated.
By their numbers in this assay, from the lowest: compounds 1, 3 and 2 (each within the scatter of the next).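

The change from 3-bromophenyl to 3-fluorophenyl alters only the halogen at this place on the ring, and in this assay it gives a 1.1-fold lower number from compound 2 to compound 3 (0.03 log units; within the scatter), so bromo and fluoro are not told apart here. The comparison with the 2-chlorophenyl of compound 1 gives a 1.3-fold higher number from compound 1 to compound 3 (0.13 log units; within the scatter) and changes both the halogen and its place, so all three compounds remain within the scatter of one another, and these data separate neither factor. No evidence is available that bears on this result.

On these data alone, whether this flat response extends beyond halogens remains open, for instance to an amine, a methoxy group or a carboxylic acid at this place. Also open, as far as these compounds go, is how a single halogen behaves when only its place on the ring changes.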